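The source may report more compounds than this note shows. Statements on the series, on what has been measured and on what is new or still open speak of the compounds shown alone.

Compound 1 `COc1ccc(/C=C/C(=O)c2cc(OC)c(OC)c(OC)c2)cc1OCCCC(=O)NCCCNCCCCNCCN` carries a long amine-bearing chain on its core. In a functional assay on HT-29 cells (Homo sapiens) for antiproliferative activity, read by MTT assay, with a stated time of 48 h (on this read-out lower numbers stand for stronger inhibition and higher numbers for weaker inhibition), compound 1 gives > 100000 nM, which is a limit of the assay and not a number. It therefore sits with no measured potency among the three compounds tested, and the same holds for one of its two companions. Compound 2 `COc1cc(C(=O)/C=C/c2ccc(OCCCC(=O)NCCCNCCCCN)cc2)cc(OC)c1OC` gives > 100000 nM, also a limit. For the measured compounds named here, compound 3 `COc1cc(C(=O)/C=C/c2ccc(OCCCC(=O)NCCCNCCCCNCCN)cc2)cc(OC)c1OC` gives 98000 nM, the only true number in the set. Together these results are summed up as the limit of > 100000 nM in this assay, at which 2 of the 3 values shown sit.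

Compound 4 `COc1ccc(/C=C/C(=O)c2cc(OC)c(OC)c(OC)c2)cc1OCCCC(=O)NCCCNCCCCN` shortens the chain of compound 1, with hydrogen in place of 2-aminoethyl on an amine nitrogen.

Going by the values given here, one measured step bears on this, the same change run in the opposite direction: an at least 1.0-fold lower number from compound 2 to compound 3 (0.00 log units; that floor lies within the scatter). That step removes no doubt about size, since one end of it is only a limit, but it gives no sign that this group matters in this assay. With compound 3 showing 98000 nM, a clear gain in potency on trimming the chain is not expected. The estimated change is a step that the limit leaves unreadable from compound 1 to compound 4, so no step beyond the scatter is expected. For compound 4 the expected value is 110000 nM, within an estimated range from 60000 nM to 200000 nM, and a report of only a limit is likely.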

Compound 4, half-maximal inhibitory concentration: > 100000 nM
Compound 4 was reported as a limit; the forecaster's own chance of this, stated with the estimate: 70%; the middle value lies beyond the limit too.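

In this assay compound 4 gives > 100000 nM, which is a limit of the assay and not a number. For the compounds shown here, compound 1 also stands at a limit, so no step from compound 1 to compound 4 can be read. The compounds shown leave open whether the 2-aminoethyl group on the amine nitrogen changes potency at all, with most results resting on one value: the limit of > 100000 nM in this assay, at which 3 of the 4 values shown sit.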